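Halogen swap on the shared core: compound 3 to compound 4

The compounds below may be only part of what the source reports. "The series", "measured", "known", "first", "only" and "open" are said of these compounds alone.

Measured in a functional assay on L132 cells (Homo sapiens) for cytotoxicity, read by MTT assay, with a stated time of 72 h; on this read-out lower numbers stand for an effect already at smaller amounts and higher numbers for an effect only at larger amounts of compound:
compound 1 `COc1ccc(/C=C2\C(=O)N(c3c(Cl)cccc3Cl)c3ccccc32)cc1OC`: > 100 ug/mL
compound 2 `O=C1/C(=C\c2cc3ccccc3nc2Cl)c2ccccc2N1c1c(Cl)cccc1Cl`: "not determined" (no result reported)
compound 3 `O=C1/C(=C\c2ccc(F)cc2)c2ccccc2N1c1c(Cl)cccc1Cl`: 13 ug/mL

In this assay compound 3 gives 13 ug/mL and is the only entry with a single number. Compound 1 sits at a limit of the assay, > 100 ug/mL, as noted in the limit of > 100 ug/mL in this assay, at which 1 of the 3 values shown sits. For compound 2 no result is reported, "not determined" (no result reported). Compound 4 `O=C1/C(=C\c2cccc(Br)c2)c2ccccc2N1c1c(Cl)cccc1Cl` differs from compound 3 by 3-bromophenyl in place of 4-fluorophenyl on a double-bonded chain carbon bound to a double-bonded ring carbon. Among the compounds with values here, no step between two measured compounds is available in this assay, so nothing here fixes how far a change of halogen and of its position on that ring moves the read-out. The working expectation is a step that stays within the usual scatter, in no fixed direction. Compound 4 is therefore expected at about 15 ug/mL, in the range 5 ug/mL to 50 ug/mL. The step this estimate means is a 1.2-fold higher number from compound 3 to compound 4 (0.06 log units; within the scatter), which is taken to lie inside the scatter.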

Compound 4, concentration for half-maximal effect: 19 ug/mL
Estimate against measurement, compound 4: 1.3-fold (0.10 log units) below; the range from low to high includes it.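

In this assay, within the data shown here, 3-bromophenyl in place of 4-fluorophenyl on a double-bonded chain carbon bound to a double-bonded ring carbon gives a 1.5-fold higher number from compound 3 to compound 4 (0.16 log units; within the scatter), the first readable step at this position. The step lies within the scatter, so this exchange of halogen and of its place on the phenyl ring leaves no change that can be told apart in this read-out. Compound 1 remains at a limit of the assay, which is not a number, so the step rests on only two single values: the limit of > 100 ug/mL in this assay, at which 1 of the 4 values shown sits.

Open, from the compounds shown here alone, is whether the kind of halogen and its place on the ring each act alone, since both differ in this one step. Also open, going by these compounds, is how the read-out responds at this position when an amine or a carboxylic acid stands on the phenyl ring in place of the halogen.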